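The source may hold more compounds than are shown below. What is called first, only, known or untested is meant among the compounds shown, and "the series" means these compounds.

Measured compounds in a functional assay on the whole organism with Rattus norvegicus as the target; on this read-out lower numbers stand for an effect already at smaller amounts and higher numbers for an effect only at larger amounts of compound:
compound 1 `CC1CCC(=NNc2ccccc2C(=O)O)c2ncc(C(=O)O)c(=O)n21` gives > 100 umol/kg, a limit of the assay.
compound 2 `CC1CCC(=NNc2ccccc2C(=O)O)c2ncc(C(=O)NO)c(=O)n21` gives > 100 umol/kg, a limit of the assay.
compound 3 `Cc1cccc(NN=C2CCC(C)n3c2ncc(C(=O)O)c3=O)c1C` gives > 100 umol/kg, a limit of the assay.

Compound 3 thus stands at the limit of > 100 umol/kg in this assay, at which 3 of the 3 values shown sit. The values of compounds 1, 2 and 3 show no readable difference among them. Going by the values given here, the only step between measured compounds, a step that the two limits leave unreadable from compound 1 to compound 2, is unreadable and concerns hydroxyamino in place of hydroxy on a carbonyl carbon, not the part altered here. Compound 4 `Cc1cc(C)cc(NN=C2CCC(C)n3c2ncc(C(=O)O)c3=O)c1` differs from compound 3 by 3,5-dimethylphenyl in place of 2,3-dimethylphenyl on an amine nitrogen. Among the compounds with values here, no measured step speaks to this change, so no step beyond the scatter is expected in this assay in either direction. For compound 4 the expected step is a step that the limit leaves unreadable from compound 3 to compound 4. Compound 4 is therefore estimated at 150 umol/kg, with a range from 50 umol/kg to 500 umol/kg, and most likely the assay again reports only a limit.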

Compound 4, dose for 50% inhibition: > 320 umol/kg
Compound 4 gave a limit, no number; the forecaster's own chance of this, stated with the estimate: 85%; middle value at least 2.1-fold (0.32 log units) from the limit.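

Compound 3 and compound 4 both give only limits of the assay, not numbers, so no step can be read between them. As far as these compounds go, whether 3,5-dimethylphenyl and 2,3-dimethylphenyl differ at all in this assay stays open.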